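Swapping a pyridine for an ethynylphenyl: solubility expectation

The source may report more compounds than this note shows. Statements on the series, on what has been measured and on what is new or still open speak of the compounds shown alone.

Measured compounds:
- Compound 1, `COc1ccc(F)cc1N1C(=O)CSC1c1cccc(C(=O)NCCCCn2cccn2)c1`: 50000 nM
- Compound 2, `O=C(NCCCCn1cccn1)c1cccc(C2SCC(=O)N2c2ccccn2)c1`: 50000 nM
- Compound 3, `O=C(NCCCCc1ccccc1)c1cccc(C2SCC(=O)N2c2ccccn2)c1`: 20000 nM

These three compounds were measured in a physicochemical assay for solubility, read by turbidimetry, measured as kinetic solubility, at pH 6.8; a higher number here means a more soluble compound, a lower number a less soluble compound. Compound 3 gives the lowest of the three numbers; both compound 1 and compound 2 sit higher by the same margin, as the step of a 2.5-fold lower number from compound 2 to compound 3 (0.40 log units; beyond the scatter) shows for compound 2.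

Compound 4, `C#Cc1cccc(N2C(=O)CSC2c2cccc(C(=O)NCCCCc3ccccc3)c2)c1`, has not yet been measured. It differs from compound 3 in one place: 3-ethynylphenyl in place of pyridin-2-yl on an amide-type nitrogen in a ring.

Among the compounds with values here, one measured step bears on this change, because it also replaces the group on the amide-type nitrogen in the ring: no change at the digits printed from compound 1 to compound 2 (within the scatter). That swap of one aromatic ring for another left the solubility where it was. The present change goes the other way, from pyridin-2-yl to an all-carbon ring carrying a triple bond, and the earlier step gives no sign that such a swap moves the number much. The expectation for compound 4 is therefore a small step, if any, probably downward, a 1.7-fold lower number from compound 3 to compound 4 (0.22 log units; within the scatter). Compound 4 is estimated at 12000 nM, with a range from 5000 nM to 30000 nM.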

Compound 4, solubility: 10000 nM
For compound 4 the middle estimate is 1.2-fold (0.08 log units) above the measured one; low and high end bracket the measured number.
By their numbers in this assay, from the lowest: compounds 4 and 3 (each within the scatter of the next); then compounds 1 and 2 (each within the scatter of the next).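

In this assay, the second ring swap at this position gives a 2.0-fold lower number from compound 3 to compound 4 (0.30 log units; within the scatter). The entering 3-ethynylphenyl has 8 heavy atoms, all carbon, and 0 hydrogen-bond acceptors, whereas the leaving pyridin-2-yl has 6 heavy atoms, including 1 nitrogen, and 1 hydrogen-bond acceptor; even so, the two compounds cannot be told apart in this measurement. The earlier swap at this position, no change at the digits printed from compound 1 to compound 2 (within the scatter), was made with 1H-pyrazol-1-yl on the chain, so the new step extends the same reading to a compound with phenyl on the chain, and no information here explains either result.

The compounds shown leave open whether a group of a different kind on the amide-type nitrogen in the ring, such as an amine-bearing ring or a carboxylic acid-bearing ring, would produce a step beyond the scatter. They also leave open how 3-ethynylphenyl at this position would read with 1H-pyrazol-1-yl in place of phenyl on the chain, and whether a longer chain would alter the picture.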